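The source may report more compounds than this note shows. Statements on the series, on what has been measured and on what is new or still open speak of the compounds shown alone.

Measured in an ADME assay on microsomes from liver (Rattus norvegicus) for metabolic stability, read by HPLC, using NADPH, with stated times of 5 min and 60 min, tested at 10 uM; on this read-out lower numbers stand for slow clearance and higher numbers for fast clearance:
- compound 1 `CCS(=O)(=O)Nc1ccc(Oc2ccc(C#N)cc2)c(-c2cn(C)c(=O)c3[nH]ccc23)c1`: 81.7 mL/min/kg
- compound 2 `CCS(=O)(=O)Nc1ccc(Oc2ccc(C(F)(F)F)cc2)c(-c2cn(C)c(=O)c3[nH]ccc23)c1`: 583 mL/min/kg
- compound 3 `Cn1cc(-c2cc(NS(C)(=O)=O)ccc2Oc2ccc(F)cc2Cl)c2cc[nH]c2c1=O`: 317 mL/min/kg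

Compound 3 lies within the scatter of compound 2, and both stand beyond the scatter above compound 1. Next is compound 4 `Cn1cc(-c2cc(NS(C)(=O)=O)ccc2Oc2cccnc2)c2cc[nH]c2c1=O`, with the change pyridin-3-yl in place of 2-chloro-4-fluorophenyl on an oxygen on an aromatic ring. Among the measured compounds shown here, no measured step makes this exact change. The nearest evidence is a 7.1-fold higher number from compound 1 to compound 2 (0.85 log units; beyond the scatter), a different substitution on the ring carried by that oxygen, so support is thin. A moderate fall in clearance is nevertheless expected, a 2.6-fold lower number from compound 3 to compound 4 (0.42 log units; beyond the scatter). Compound 4 is estimated at 120 mL/min/kg, with an expected range of 40 mL/min/kg to 350 mL/min/kg.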

Compound 4, clearance: 350 mL/min/kg
Estimate against measurement, compound 4: 2.9-fold (0.46 log units) below, and the stated range covers the measured number.
By their numbers in this assay, from the lowest: compound 1; then compounds 3, 4 and 2 (each within the scatter of the next).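

Pyridin-3-yl in place of 2-chloro-4-fluorophenyl on an oxygen on an aromatic ring gives a 1.1-fold higher number from compound 3 to compound 4 (0.04 log units; within the scatter) in this assay, so this exchange does not separate the two compounds on clearance. They remain within the scatter even though a ring of carbon only, carrying chlorine and fluorine, gives way to a ring with one hetero atom and one hydrogen-bond acceptor. Nothing at hand accounts for this result.

From the compounds shown here alone, it remains open whether a nitrile or a trifluoromethyl on the pyridin-3-yl ring would shift clearance in this methanesulfonamide series. A carboxylic acid or an amine at this position also remains untested among the compounds shown.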